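Ester to Acid and Metabolic Stability in Liver Fraction

The compounds below may be only part of what the source reports. "The series", "measured", "known", "first", "only" and "open" are said of these compounds alone.

Of the compounds shown here, three have so far been measured in an ADME assay on S9 fraction from liver (Rattus norvegicus) for metabolic stability, read by LC-MS, using NADPH, with a stated time of 30 min; a higher number here means that more of the compound is left, a lower number that less of the compound is left. Compound 1 `CCCCCCCCc1ccc(OCC(=O)Cn2nnc(-c3ccc(C(=O)OC)cc3)n2)cc1` gives 64%. Compound 3 `CCCCCCCCc1ccc(OC(C)C(=O)Cn2nnc(-c3ccc(C(=O)OC)cc3)n2)cc1` gives 62%. Compound 2 `CCCCCCCCc1ccc(OCC(=O)Cn2nnc(-c3ccc(C(=O)O)cc3)n2)cc1` gives a value that is a limit of the assay rather than a number, < 5%. Compound 4 `CCCCCCCCc1ccc(OC(C)C(=O)Cn2nnc(-c3ccc(C(=O)O)cc3)n2)cc1` has not yet been measured.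

Compound 2 differs from compound 1 by hydrogen in place of methyl on an oxygen next to a carbonyl group, and this change brought a number at least 59 percentage points lower from compound 1 to compound 2 (beyond the scatter). Compound 3 differs from compound 1 by methyl in place of hydrogen on a saturated chain carbon bound to a carbonyl carbon and an oxygen on an aromatic ring, and that change brought a number 2 percentage points lower from compound 1 to compound 3 (within the scatter), so the values of compound 1 and compound 3 sit within the scatter of each other.

Compound 4 differs from compound 3 by hydrogen in place of methyl on an oxygen next to a carbonyl group. Among the measured compounds shown here, this is the same change as the one from compound 1 to compound 2, made at the same place. the limit of < 5% in this assay, at which 1 of the 3 values shown sits, marks where compound 2 sits.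

For compound 4 a step of about the same size is expected, resting on a number at least 59 percentage points lower from compound 1 to compound 2 (beyond the scatter). The core change from compound 1 to compound 3 produced only a number 2 percentage points lower from compound 1 to compound 3 (within the scatter), so the core of compound 3 gives no sign of altering the outcome. The step of a number 59 percentage points lower from compound 3 to compound 4 (beyond the scatter) is the one estimated here. Compound 4 is expected to give 3%, with 0% to 10% as the expected span, and it will most likely be reported as the assay's limit rather than a number.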

Compound 4, percent of the compound remaining: 55%
For compound 4 the middle estimate is 52 percentage points below the measured one; the measured number lies above the stated range.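

Moving from methoxycarbonyl to carboxy does not carry over cleanly between these two cores in this assay: on the core of compound 3 the change gave a number 7 percentage points lower from compound 3 to compound 4 (within the scatter), and the two steps differ: the same change on two cores in this assay, a number at least 59 percentage points lower (beyond the scatter) from compound 1 to compound 2 and a number 7 percentage points lower (within the scatter) from compound 3 to compound 4, at least 52 percentage points apart, beyond the scatter of two such steps

The methyl on the saturated chain carbon tells the same story from the other side, since adding it to the carboxylic acid gave a number at least 50 percentage points higher from compound 2 to compound 4 (beyond the scatter), and this step does not match the one seen with the methyl ester: the same change on two cores in this assay, a number 2 percentage points lower (within the scatter) from compound 1 to compound 3 and a number at least 50 percentage points higher (beyond the scatter) from compound 2 to compound 4, at least 52 percentage points apart, beyond the scatter of two such steps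

The four compounds therefore show that, in this series, the outcome of exchanging the ester for the acid depends on the core that carries it, but they do not show why, and they say nothing about how the exchange would behave on any other core.

Among the compounds shown here, it remains open whether a methyl is the only group at that chain carbon that goes with a high percentage remaining for the acid, or whether an ethyl or a fluorine there would do the same. Also open, on these data alone, is whether the contrast between the two acids would persist with a shorter chain in place of the long alkyl chain on the far aromatic ring, or with an amide in place of the acid.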